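A few compounds are considered here, and "the series" means these few. Any claim that something is new, unique, unknown or untested is made for them only; others in the source may bear on it.

Measured in a functional assay on A549 cells (Homo sapiens) for inhibition, read by MTT assay, with a stated time of 72 h; on this read-out lower numbers stand for stronger inhibition and higher numbers for weaker inhibition:

Compound 1 `Nc1ncnc2c1c(-c1cnc3[nH]ccc3c1)nn2CCCCCCCCC(=O)NO`: 12300 nM
Compound 2 `Nc1nc2cc(-c3nn(CCCC(=O)NO)c4ncnc(N)c34)ccc2o1`: > 100000 nM
Compound 3 `Nc1ncnc2c1c(-c1cnc3[nH]ccc3c1)nn2CCCC(=O)NO`: > 150000 nM

Compound 2 has no exact number: > 100000 nM is a limit of the assay. The same is true of compound 3, as the limit of > 150000 nM in this assay, at which 1 of the 3 values shown sits, records.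

Compound 4 `CNC(=O)CCCCCCCn1nc(-c2ccc3oc(N)nc3c2)c2c(N)ncnc21` carries 4-(methylcarbamoyl)butyl in place of hydroxycarbamoyl on a saturated chain carbon, three bonds along the chain from an aromatic nitrogen.

Within the data shown here, the one measured step that bears on this is an at least 12-fold higher number from compound 1 to compound 3 (1.08 log units; beyond the scatter). It swaps 5-(hydroxycarbamoyl)pentyl for hydroxycarbamoyl at that same place, and it is large. Read backwards, it suggests that the larger group in compound 4 should lower the number. However, that step keeps the hydroxycarbamoyl end, whereas compound 4 ends in methylcarbamoyl, and no measured pair isolates that change. The gain may therefore be smaller, and the result may again be only a limit.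

The expected change is an at least 2.2-fold lower number from compound 2 to compound 4 (0.34 log units; beyond the scatter), towards stronger inhibition. Compound 4 is estimated at 45000 nM, with an expected range of 12000 nM to 150000 nM.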

Compound 4, half-maximal inhibitory concentration: 8360 nM
Beside the measured number, compound 4's estimate is 5.4-fold (0.73 log units) above it; measured number outside the range, below it.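

Replacing hydroxycarbamoyl with 4-(methylcarbamoyl)butyl at this place on the chain gives an at least 11-fold lower number from compound 2 to compound 4 (1.07 log units; beyond the scatter) in this assay. Compound 2 has only a limit, not an exact number: the limit of > 100000 nM in this assay, at which 1 of the 4 values shown sits. All the earlier compounds end in hydroxycarbamoyl, so compound 4 is the only one shown that reaches a measured value in this assay with a methylcarbamoyl end instead.

This one step lengthens the chain and changes its end group together, and the compounds shown do not separate the two. A long chain on the core of compound 2 ending in hydroxycarbamoyl, a carboxylic acid or an amine would help show how much the chain length and the end group each contribute.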